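Hydroxy to amino on the side chain: cytotoxicity notes

This account rests on a few compounds, and the source may have more. Where it says the series, first, only, none or still open, it means among the compounds named here.

Measured so far:
compound 1 `OCCNC(=S)Nc1ccnc2cc(Cl)ccc12` — > 50000 nM
compound 2 `S=C(Nc1ccnc2cc(Cl)ccc12)N1CCN(CC2CCCCC2)CC1` — > 50000 nM

The read-out throughout is a functional assay on HeLa cells (Homo sapiens) for cytotoxicity, read by MTT assay, with a stated time of 7 h; a lower number here means a stronger inhibitor, a higher number a weaker inhibitor. Compound 1 gives no number there, only the limit > 50000 nM. Compound 2 likewise returns only the limit > 50000 nM. Among the compounds with values here, both values therefore sit at the limit of > 50000 nM in this assay, at which 2 of the 2 values shown sit, so compound 1 stands at the same limit as the only other measured compound and nothing places it above or below it.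

Compound 3 `NCCNC(=S)Nc1ccnc2cc(Cl)ccc12` is the next candidate. Against compound 1 the change is amino in place of hydroxy on a saturated chain carbon, two bonds along the chain from an amide-type nitrogen. Within the data shown here, no measured pair in this set differs in one place, so no step size is known from data. With both measured values at the limit, the expectation is that this change produces no step beyond the scatter in this assay, and that compound 3 will again fall at the limit rather than give a number. The estimate for compound 3 is 50000 nM, ranging from 20000 nM to 150000 nM, which means an expected step of a number no higher from compound 1 to compound 3 (the limit leaves the size open).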

Compound 3, half-maximal inhibitory concentration: 18000 nM
The estimate for compound 3 lay 2.8-fold (0.44 log units) above the measured number; measured number below the stated range.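

In this assay, amino in place of hydroxy on a saturated chain carbon, two bonds along the chain from an amide-type nitrogen, gives an at least 2.7-fold lower number from compound 1 to compound 3 (0.44 log units; beyond the scatter). Within the data shown here, this shows that a change at this place on the side chain can bring the series off the limit, which compound 1 and compound 2 could not show, and compound 3 is the only compound here that gives a number rather than a limit: the limit of > 50000 nM in this assay, at which 2 of the 3 values shown sit. The group that leaves and the group that enters match in heavy-atom count, hydrogen-bond donors, hydrogen-bond acceptors and net charge, so the step follows a swap of one oxygen for one nitrogen on an otherwise identical structure.

From the compounds shown here alone, compound 1 holds only a limit, so the full size of the step remains open, and compound 2 differs from compound 3 in more than one place and gives no direct comparison. Also open, going by these compounds, is whether the gain needs the primary amine itself, which a dimethylamino group, an acetamide, a carboxylic acid or a longer chain carrying the amine in the same place would help to settle.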